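Swapping amino for methylsulfanyl on compound 3

This account rests on a few compounds, and the source may have more. Where it says the series, first, only, none or still open, it means among the compounds named here.

Compound 1 `COc1ccc2c(/C=C/C(=O)c3cc(OC)c(OC)c(SC)c3)c[nH]c2c1` gives 112 nM
Compound 2 `COc1ccc2c(/C=C/C(=O)c3cc(N)c(OC)c(OC)c3)c[nH]c2c1` gives 186 nM
Compound 3 `COc1ccc2c(/C=C/C(=O)c3cc(N)c(OC)c(OC)c3)cn(C)c2c1` gives 198 nM

These numbers all come from a functional assay on MHCC97H cells (Homo sapiens) for antiproliferative activity, read by MTT assay, with a stated time of 48 h (a lower number here means a stronger inhibitor, a higher number a weaker inhibitor), and they cannot be ranked, since compound 3 lies within the scatter of both compound 1 and compound 2.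

The next compound, compound 4 `COc1ccc2c(/C=C/C(=O)c3cc(OC)c(OC)c(SC)c3)cn(C)c2c1`, is compound 3 with methylsulfanyl in place of amino on an aromatic carbon. The closest evidence is the same exchange run the other way, amino in place of methylsulfanyl, which gave a 1.7-fold higher number from compound 1 to compound 2 (0.22 log units; within the scatter) in the pair that carries hydrogen on the aromatic nitrogen. The methyl on that nitrogen gave a 1.1-fold higher number from compound 2 to compound 3 (0.03 log units; within the scatter) on its own. Both steps stay within the scatter, so no step beyond the scatter is expected in this assay, and any drift should run towards a lower number. The expected change is a 1.7-fold lower number from compound 3 to compound 4 (0.22 log units; within the scatter) on this estimate. For compound 4 the estimated value is 120 nM and the expected range runs from 60 nM to 240 nM in this estimate.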

Compound 4, half-maximal inhibitory concentration: 122 nM
Compound 4: middle estimate off by 1.0-fold (0.01 log units), on the low side, and the stated range covers the measured number.
By their numbers in this assay, from the lowest: compounds 1, 4, 2 and 3 (each within the scatter of the next).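

Compound 4 completes a set of four compounds, so each of the two changes can now be read on two cores in this assay. Methylsulfanyl in place of amino on this aromatic carbon gives a 1.6-fold lower number from compound 3 to compound 4 (0.21 log units; within the scatter), and this step has much the same size whether the aromatic nitrogen carries hydrogen or methyl: the same change on two cores in this assay, a 1.7-fold higher number (0.22 log units; within the scatter) from compound 1 to compound 2 and a 1.6-fold higher number (0.21 log units; within the scatter) from compound 4 to compound 3, 1.0-fold (0.01 log units) apart, within the scatter of two such steps Methyl in place of hydrogen on that nitrogen gives a 1.1-fold higher number from compound 1 to compound 4 (0.04 log units; within the scatter), and it too has much the same size with either group on the aromatic carbon: the same change on two cores in this assay, a 1.1-fold higher number (0.03 log units; within the scatter) from compound 2 to compound 3 and a 1.1-fold higher number (0.04 log units; within the scatter) from compound 1 to compound 4, 1.0-fold (0.01 log units) apart, within the scatter of two such steps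

All of these steps stay within the scatter, so the four compounds cannot be ranked. From the compounds shown here alone, it remains open whether a hydroxyl or an ethylsulfanyl group on this aromatic carbon, or an ethyl group on the aromatic nitrogen, would shift the number beyond the scatter.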